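Pentyl in place of cyclohexyl on the amide nitrogen

A few compounds are considered here, and "the series" means these few. Any claim that something is new, unique, unknown or untested is made for them only; others in the source may bear on it.

Compound 1 `C=CC1=C(C(=O)NC(C)(C)C)C(c2ccc(OC)cc2)OC1`: > 100000 nM
Compound 2 `C=CC1=C(C(=O)Nc2ccc(OCC)cc2)C(c2ccc(OC)cc2)OC1`: 17600 nM
Compound 3 `C=CC1=C(C(=O)NC2CCCCC2)C(c2ccc(OC)cc2)OC1`: > 100000 nM

In a functional assay on A549 cells (Homo sapiens) for cytotoxicity, read by MTT assay, with a stated time of 24 h (a higher number here means a weaker inhibitor, a lower number a stronger inhibitor), compound 1 reaches only a limit of the assay, > 100000 nM. Compound 2 gives a number in this assay, 17600 nM. Compound 3 again reaches only a limit, > 100000 nM. Compound 3 therefore stands at the limit of > 100000 nM in this assay, at which 2 of the 3 values shown sit, where compound 1 also sits, and the step of an at least 5.6-fold higher number from compound 2 to compound 3 (0.75 log units; beyond the scatter) is at least modest, as is an at least 5.6-fold lower number from compound 1 to compound 2 (0.75 log units; beyond the scatter), whereas a step that the two limits leave unreadable from compound 1 to compound 3 cannot be read.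

Compound 4 `C=CC1=C(C(=O)NCCCCC)C(c2ccc(OC)cc2)OC1` differs from compound 3 by pentyl in place of cyclohexyl on an amide-type nitrogen. Within the data shown here, no measured step changes one group without a ring for another; the only readable steps in this assay run between an aromatic group and a group without one. Both compounds bearing a group without an aromatic ring on that nitrogen, compound 1 and compound 3, sit at the limit, and pentyl has no ring. The step that the limit leaves unreadable from compound 3 to compound 4 is therefore expected to be none beyond the scatter. Compound 4 is estimated at 150000 nM, with a range from 50000 nM to 400000 nM, and is expected most likely to be reported again only as a limit.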

Compound 4, half-maximal inhibitory concentration: 36500 nM
Compound 4: middle estimate off by 4.1-fold (0.61 log units), on the high side; the measured number lies below the stated range.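

In this assay, among these compounds, pentyl is the only group without an aromatic ring on the amide-type nitrogen that gives a number, so an aromatic group there is not required for a reading, as an at least 2.7-fold lower number from compound 3 to compound 4 (0.43 log units; beyond the scatter) and an at least 2.7-fold lower number from compound 1 to compound 4 (0.43 log units; beyond the scatter) show. The aromatic group still keeps an edge, though a small one, with a 2.1-fold higher number from compound 2 to compound 4 (0.32 log units; beyond the scatter). Compound 1 and compound 3 remain at a limit of the assay: the limit of > 100000 nM in this assay, at which 2 of the 4 values shown sit.

As far as these compounds go, what stays open is whether the open chain itself matters or its length, which a butyl or an octyl chain on the same nitrogen would begin to separate. From the compounds shown here alone, it is also open whether a benzyl group, or an amine at the end of the pentyl chain, would move the number in either direction.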